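Swapping 2-hydroxyphenyl for 4-aminophenyl at a cytotoxicity limit

The source may report more compounds than this note shows. Statements on the series, on what has been measured and on what is new or still open speak of the compounds shown alone.

In a functional assay on HT29-AK cells (Homo sapiens) for cytotoxicity, read by MTT assay, with a stated time of 48 h (a higher number here means a weaker inhibitor, a lower number a stronger inhibitor), compound 1 `Fc1ccc(Nc2nc(-c3cccc(F)c3)nc3ccc(F)cc23)cc1` gives > 50000 nM, which is a limit of the assay and not a number. Compound 2 `Oc1ccccc1Nc1nc(-c2cccc(F)c2)nc2ccc(F)cc12` gives > 50000 nM, also a limit, so its position is known only as a limit. Compound 3 `Nc1ccc(Nc2nc(-c3cccc(F)c3)nc3ccc(F)cc23)cc1` differs from compound 2 by one change, 4-aminophenyl in place of 2-hydroxyphenyl on a nitrogen on an aromatic ring. For the measured compounds named here, the one measured step, a step that the two limits leave unreadable from compound 1 to compound 2, offers no size to carry over. The evidence consists of the limit of > 50000 nM in this assay, at which 2 of the 2 values shown sit, so no step beyond the scatter is expected in this assay, and no direction can be assigned. The expected step is a number no higher from compound 2 to compound 3 (the limit leaves the size open). Compound 3 is expected at 50000 nM, with an estimated range from 20000 nM to 80000 nM.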

Compound 3, half-maximal inhibitory concentration: > 50000 nM
Compound 3: a limit, no number (the forecaster's own chance of this, stated with the estimate: 70%); the middle value sits exactly at the limit.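

For the compounds shown here, no step among compound 1, compound 2 and compound 3 can be read in this assay because each value is only a limit: the limit of > 50000 nM in this assay, at which 3 of the 3 values shown sit. The compounds shown leave open whether 4-fluorophenyl, 2-hydroxyphenyl and 4-aminophenyl on that nitrogen differ at all in cytotoxicity.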